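A Cyanopyridine in Place of a Thiazole

This account rests on a few compounds, and the source may have more. Where it says the series, first, only, none or still open, it means among the compounds named here.

Among the measured compounds shown here, compound 1 `Cc1cccc(NC(=O)CN2CCC(c3nccs3)CC2)c1` gives 62% in a functional assay on HEK293 cells for agonist activity at D(4) dopamine receptor (Homo sapiens), read by FLIPR (on this read-out higher numbers stand for larger maximal responses and lower numbers for smaller maximal responses), the higher of the two numbers known so far. Compound 2 `CC(C)Oc1cccc(NC(=O)CN2CCC(c3cccc[n+]3[O-])CC2)c1` gives 48% in this assay, and the gap between these two values is beyond the usual scatter. Compound 3 `Cc1cccc(NC(=O)CN2CCC(c3cccc(C#N)n3)CC2)c1` has not yet been measured; it differs from compound 1 by 6-cyanopyridin-2-yl in place of 1,3-thiazol-2-yl on a saturated ring carbon. For the measured compounds named here, no step between measured compounds that differ in one place is known, so the expected change is a modest fall from compound 1 to compound 3, close to the scatter: a number 8 percentage points lower from compound 1 to compound 3 (within the scatter). Compound 3 is therefore expected to reach about 54%, estimated between 35% and 73%.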

Compound 3, largest response reached (reported as efficacy), in percent of the reference or control that the assay uses: 42%
Compound 3: middle estimate off by 12 percentage points, on the high side, and the stated range covers the measured number.
By their numbers in this assay, from the lowest: compounds 3 and 2 (each within the scatter of the next); then compound 1.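

Among the compounds shown here, on a saturated ring carbon of the shared core, 6-cyanopyridin-2-yl in place of 1,3-thiazol-2-yl gives a number 20 percentage points lower from compound 1 to compound 3 (beyond the scatter) in this assay, the first comparison here of compounds that differ in one place. It shows that the maximal response depends on which aromatic group sits at this position. Nothing available explains this fall.

The change replaces the ring and adds the nitrile together, so the compounds shown leave open which of the two goes with the fall. A plain pyridin-2-yl at this position, without the nitrile, would separate them.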